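A few compounds are considered here, and "the series" means these few. Any claim that something is new, unique, unknown or untested is made for them only; others in the source may bear on it.

Compound 1, `Cc1cccc(Cc2nc(N)c3nn(-c4ccccc4)cc3n2)c1`, in an assay on CHO cells for displacement of a labelled ligand from adenosine receptor A3 (Homo sapiens), read by scintillation counting, tested at 1 uM; a lower number here means less inhibition, a higher number more inhibition at the concentration tested (going by the name of the read-out): 11%
Compound 2, `Nc1nc(Cc2cccc(C(F)(F)F)c2)nc2cn(-c3ccccc3)nc12`, in this assay: 41%
Compound 3, `Nc1nc(Cc2cccc(Cl)c2)nc2cn(-c3ccccc3)nc12`, in this assay: 42%

Compound 3 stands highest of the three numbers, but its nearest neighbour is compound 2, and the two differ only by a number 1 percentage points higher from compound 2 to compound 3 (within the scatter), so they cannot be told apart. Compound 1 is furthest away: the steps of a number 30 percentage points higher from compound 1 to compound 2 (beyond the scatter) and a number 31 percentage points higher from compound 1 to compound 3 (beyond the scatter) both lie beyond the scatter.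

The unmeasured compound 4, `Nc1nc(/C=C/c2ccccc2)nc2cn(-c3ccccc3)nc12`, differs from compound 3 in one place: 2-phenylethenyl in place of 3-chlorobenzyl on an aromatic carbon. For the measured compounds named here, none of the measured steps bears directly on this change. All three measured compounds keep a benzyl group at the same place, and the steps only exchange the group on its ring, methyl for trifluoromethyl or chloro. Those exchanges alone moved the number by a modest to large amount, so replacing the whole group could move it either way. Because compound 3 gives 42% and compound 1 gives 11%, the estimate for compound 4 is placed between the two with a wide range. Compound 4 is expected at 25%, between 5% and 55%, with a number 17 percentage points lower from compound 3 to compound 4 (beyond the scatter) expected as a downward but uncertain step.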

Compound 4, a percentage reported as inhibition, at one concentration (the size of the read-out at that concentration, not a potency): 25%
The estimate for compound 4 equals the measured number at the digits printed, within the range that was stated.
By their numbers in this assay, from the lowest: compound 1; then compound 4; then compounds 2 and 3 (each within the scatter of the next).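

Until now only the small group on the benzyl ring had changed, whereas here the whole 3-chlorobenzyl group on the aromatic carbon between two ring nitrogen atoms gives way to 2-phenylethenyl, which has the same number of heavy atoms and adds a double bond outside aromatic rings. In this assay this exchange gives a number 17 percentage points lower from compound 3 to compound 4 (beyond the scatter) while the same 2-phenylethenyl group, set against 3-methylbenzyl, gives a number 14 percentage points higher from compound 1 to compound 4 (beyond the scatter) so the change has no single direction and its outcome depends on which benzyl group it replaces. The position therefore responds to the whole group as well as to the small group on its ring, but nothing available here gives a reason for either step.

The compounds shown leave open how a saturated 2-phenylethyl group, or a phenyl ring joined directly to the same carbon, would compare with 2-phenylethenyl. As far as these compounds go, it also remains open whether a chloro or trifluoromethyl group on the ring of 2-phenylethenyl would raise the number as it did on the benzyl ring.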